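This account rests on a few compounds, and the source may have more. Where it says the series, first, only, none or still open, it means among the compounds named here.

Measured compounds:
compound 1 `CCCOc1ccc2oc(/C=C/[S+](C)[O-])cc(=O)c2c1` gives 6200 nM
compound 2 `C[S+]([O-])/C=C/c1cc(=O)c2cc(F)ccc2o1` gives 7000 nM
compound 3 `CCCCCOc1ccc2oc(/C=C/[S+](C)[O-])cc(=O)c2c1` gives 6600 nM

All three numbers come from a functional assay on DLD-1 cells (Homo sapiens) for cytotoxicity, with a stated time of 48 h; a higher number here means a weaker inhibitor, a lower number a stronger inhibitor. Compound 3 holds the second highest of the three, but the spread is small: the nearest is compound 2, with a 1.1-fold lower number from compound 2 to compound 3 (0.03 log units; within the scatter), and the furthest is compound 1, with a 1.1-fold higher number from compound 1 to compound 3 (0.03 log units; within the scatter), so none of the three can be set apart from the others.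

Compound 4 `COc1ccc2oc(/C=C/[S+](C)[O-])cc(=O)c2c1` is not yet measured. Against compound 3 the difference is hydrogen in place of butyl on a saturated chain carbon bound to an oxygen on an aromatic ring.

Going by the values given here, the steps that bear on this are those touching the same side chain. Lengthening the chain, a 1.1-fold higher number from compound 1 to compound 3 (0.03 log units; within the scatter), left the number where it was. Removing the alkoxy group altogether in favour of fluoro, a 1.1-fold higher number from compound 1 to compound 2 (0.05 log units; within the scatter), or putting pentyloxy back in its place, a 1.1-fold lower number from compound 2 to compound 3 (0.03 log units; within the scatter), likewise stayed within the scatter. Shortening the chain from pentyloxy to methoxy is a change of the same kind, and nothing measured suggests it should move this assay beyond the scatter in either direction.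

For compound 4 the step from compound 3 is therefore expected to be no change at the digits printed from compound 3 to compound 4 (within the scatter). The estimate for compound 4 in this assay is 6600 nM, with a range from 3300 nM to 13000 nM.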

Compound 4, half-maximal inhibitory concentration: 5700 nM
Beside the measured number, compound 4's estimate is 1.2-fold (0.06 log units) above it; measured number inside the range.
By their numbers in this assay, from the lowest: compounds 4, 1, 3 and 2 (each within the scatter of the next).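

In this assay, the step to methoxy lies within the scatter. The earlier steps shown here lie within the scatter too: cutting back from pentyloxy gives a 1.2-fold lower number from compound 3 to compound 4 (0.06 log units; within the scatter), and cutting back from propoxy gives a 1.1-fold lower number from compound 1 to compound 4 (0.04 log units; within the scatter). With methoxy, propoxy and pentyloxy now all on this aromatic carbon, chain length has no readable effect on the number across these three compounds, and methoxy in place of fluoro, a 1.2-fold lower number from compound 2 to compound 4 (0.09 log units; within the scatter), shows that fluoro cannot be set apart from methoxy either. No measurement here offers an explanation for this flat result.

As far as these compounds go, whether this aromatic carbon tolerates anything more distinct remains open, since an amine, a carboxylic acid, a hydroxyl or a chain longer than pentyloxy could still move the number beyond the scatter. The group on the other side of the shared core is also the same in all four compounds, so these values cannot show whether the number depends on that part of the structure or whether this flat pattern would hold outside this cell assay.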